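Removing a methoxycarbonyl group: what happens to compound 4?

The source may hold more compounds than are shown below. What is called first, only, known or untested is meant among the compounds shown, and "the series" means these compounds.

Measured so far:
compound 1, `Nc1ccccc1NC(=O)c1ccc(CSC(=S)N2CCc3ccc([N+](=O)[O-])cc32)cc1`, 30.6%
compound 2, `CN1CCN(C(=S)SCc2ccc(C(=O)Nc3ccccc3N)cc2)CC1`, 29.6%
compound 3, `COC(=O)c1ccc2c(c1)CCN2C(=S)SCc1ccc(C(=O)Nc2ccccc2N)cc1`, 37.8%

All three compounds share one read-out, a functional assay on MGC-803 cells (Homo sapiens) for antiproliferative activity, read by CCK-8 assay, with a stated time of 72 h, tested at 2 uM; a lower number here means a weaker effect, a higher number a stronger effect of the compound at the concentration tested. In this assay compound 3 gives the largest of the three numbers, but the gap to compound 1 and the gap to compound 2 both lie within the usual scatter of repeated measurements, so the three values cannot be told apart with confidence.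

Compound 4, `Nc1ccccc1NC(=O)c1ccc(CSC(=S)N2CCc3ccccc32)cc1`, has not yet been measured. It differs from compound 3 in one place: hydrogen in place of methoxycarbonyl on an aromatic carbon. The methoxycarbonyl group is simply gone, and a hydrogen stands where it was.

Among the compounds with values here, no pair of measured compounds differs in exactly one place, so there is no measured step to lean on. Within the data shown here, the three numbers so far sit close together despite differences on the same ring and beyond it, which suggests that changes here move the read-out little. The step from compound 3 to compound 4 in this assay is therefore expected to be small, perhaps slightly downward, and not beyond the scatter: a number 6.8 percentage points lower from compound 3 to compound 4 (within the scatter). Compound 4 is expected to give about 31%, with a range from 18% to 44%.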

Compound 4, a percentage reported as inhibition, at one concentration (the size of the read-out at that concentration, not a potency): 44%
Estimate against measurement, compound 4: 13 percentage points below; the measured number falls inside the stated range.
By their numbers in this assay, from the lowest: compounds 2, 1, 3 and 4 (each within the scatter of the next, the first and the last beyond it).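

In this assay, taking away the methoxycarbonyl group and leaving a hydrogen on the aromatic carbon gives a number 6.2 percentage points higher from compound 3 to compound 4 (within the scatter) and so produces no change that can be told from scatter, which means this ester is not needed to keep the read-out at this position. Hydrogen in place of nitro on an aromatic carbon gives a number 13.4 percentage points higher from compound 1 to compound 4 (beyond the scatter) and is a modest gain that does stand out from the scatter, so the substituent on this ring can matter even though removing the methoxycarbonyl group shows no clear effect. A change at the other end of the thiocarbonyl carbon also counts: 2,3-dihydro-1H-indol-1-yl in place of 4-methylpiperazin-1-yl gives a number 14.4 percentage points higher from compound 2 to compound 4 (beyond the scatter) and is likewise modest but beyond the scatter.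

Nothing shown here explains any of these steps. As far as these compounds go, whether a small group such as an amine, a carboxylic acid or a methyl on the same aromatic carbon would keep, raise or lower the read-out stays open, as does whether these differences hold at other concentrations or in other cell lines.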